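Pentyl for phenyl on the shared core

The source may report more compounds than this note shows. Statements on the series, on what has been measured and on what is new or still open speak of the compounds shown alone.

Of the compounds shown here, two have numbers so far. Compound 1 `CCCCCc1cc2nn(-c3ccccc3)cc2c(C)n1` in a functional assay on MCF7 cells (Homo sapiens) for inhibition, read by fluorescence, with a stated time of 72 h (on this read-out lower numbers stand for stronger inhibition of growth and higher numbers for weaker inhibition of growth), gives 17000 nM. Compound 2 `c1ccc(-c2cc3nn(-c4ccccc4)cc3cn2)cc1` in this assay gives 4800 nM, which is the lower of the two numbers; compound 1 stands at a higher number, and the gap between them lies beyond the usual scatter. Among the measured compounds shown here, compound 1 and compound 2 differ in more than one place, so no single step between measured compounds is available.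

Compound 3 `CCCCCc1cc2nn(-c3ccccc3)cc2cn1` has not been measured in this assay. It differs from compound 2 in one place: pentyl in place of phenyl on an aromatic carbon. Compound 1 also carries pentyl at the same position, and its number in this assay is the higher of the two known, but it differs from compound 3 elsewhere as well, so the known numbers give only a loose indication. A step toward a higher number is expected, of moderate size, a 2.5-fold higher number from compound 2 to compound 3 (0.40 log units; beyond the scatter). Compound 3 is estimated at 12000 nM in this assay, with a range from 4000 nM to 36000 nM.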

Compound 3, concentration for 50% growth inhibition: 11800 nM
Estimate against measurement, compound 3: 1.0-fold (0.01 log units) above, within the range that was stated.
By their numbers in this assay, from the lowest: compound 2; then compounds 3 and 1 (each within the scatter of the next).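

In this assay the aromatic carbon next to the ring nitrogen now has a comparison that changes one group only: pentyl in place of phenyl gives a 2.5-fold higher number from compound 2 to compound 3 (0.39 log units; beyond the scatter) and thus a modest step that favours phenyl over pentyl at this place on the shared core. Among the compounds shown here, with pentyl held fixed, hydrogen in place of methyl gives a 1.4-fold lower number from compound 1 to compound 3 (0.16 log units; within the scatter) and so the methyl of compound 1 makes no readable difference in this pair, which leaves the pentyl-for-phenyl change as the only measured single step beyond the scatter. No measurement at hand bears on why phenyl and pentyl differ at this position.

Going by these compounds, whether the step follows the loss of the aromatic ring or the presence of the chain stays open, as only these two groups stand at this position, and a cyclohexyl ring, a shorter chain such as ethyl or an amine would help to separate those readings. On these data alone, whether methyl makes as little difference alongside phenyl also stays open, since the methyl comparison rests on the pentyl pair alone.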